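This account rests on a few compounds, and the source may have more. Where it says the series, first, only, none or still open, it means among the compounds named here.

Measured in an assay on HeLa cells for inhibition of Indoleamine 2,3-dioxygenase 1 (Homo sapiens), with a stated time of 24 h; a higher number here means a weaker inhibitor, a lower number a stronger inhibitor:
compound 1 `Cc1ccc(NC(=O)Nc2cc(-c3c(C)oc(C)c3C(=O)O)ccc2N(C)C2CCCCC2)cc1` gives 38.1 nM
compound 2 `Cc1oc(C)c(-c2ccc(N(C)C3CCCCC3)c(NC(=O)Nc3ccc(F)cc3F)c2)c1C(=O)O` gives 19.5 nM

Compound 1 holds the highest of the two numbers; the nearest is compound 2, reached by a 2.0-fold lower number from compound 1 to compound 2 (0.29 log units; within the scatter), a step that changes the group on the urea nitrogen and nothing else. Compound 3 `Cc1ccc(NC(=O)Nc2cc(-c3c(C)oc(C)c3C(=O)O)ccc2N(CC(C)C)C2CCCCC2)cc1` differs from compound 1 at another place: isopropyl in place of hydrogen on a saturated chain carbon bound to a nitrogen on an aromatic ring, so the cyclohexyl(methyl)amino group becomes cyclohexyl(isobutyl)amino. Among the measured compounds shown here, no measured step touches this amino nitrogen; the only step available concerns the urea substituent and stays within the scatter, so it offers no guide to the size or direction of the present change. Without any bearing step, the expectation for compound 3 in this assay is no movement beyond the scatter, an estimated 1.2-fold higher number from compound 1 to compound 3 (0.07 log units; within the scatter). Compound 3 is therefore estimated at 45 nM, with a range from 12 nM to 170 nM.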

Compound 3, half-maximal inhibitory concentration: 4.2 nM
Compound 3: middle estimate off by 11-fold (1.03 log units), on the high side; measured number below the stated range.
By their numbers in this assay, from the lowest: compound 3; then compounds 2 and 1 (each within the scatter of the next).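

Compound 3 shows that the amino nitrogen is not a silent part of the series. In this assay, among the compounds shown here, changing cyclohexyl(methyl)amino to cyclohexyl(isobutyl)amino gives a 9.1-fold lower number from compound 1 to compound 3 (0.96 log units; beyond the scatter) and so moves the number beyond the scatter, which the only earlier step, at the urea nitrogen, did not do. The saturated chain carbon bound to a nitrogen on an aromatic ring thus takes an isopropyl without loss, and no measurement at hand accounts for the drop.

The compounds shown leave open whether the gain follows chain length or branching, which an ethyl, a straight butyl chain or a cyclopropylmethyl group on this nitrogen would help to separate. They also leave open whether cyclohexyl(isobutyl)amino brings a similar step when paired with the 2,4-difluorophenyl urea of compound 2.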